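The compounds below may be only part of what the source reports. "The series", "measured", "known", "first", "only" and "open" are said of these compounds alone.

Measured so far in a functional assay on A549 cells (Homo sapiens) for cytotoxicity, read by sulforhodamine B assay; a lower number here means a stronger inhibitor, a higher number a weaker inhibitor:

- compound 1 `COc1cc([C@@H]2Oc3c(OC)cc(CCCO)cc3[C@H]2CO[C@@H]2O[C@@H](C)[C@H](O)[C@@H](O)[C@H]2O)cc(OC)c1O`: > 10000 nM.
- compound 2 `COc1cc(C[C@@H]2CO[C@@H](c3ccc(O)c(OC)c3)[C@@H]2CO[C@@H]2O[C@@H](C)[C@H](O)[C@@H](O)[C@H]2O)ccc1O`: > 10000 nM.

The figure of compound 1 is not a number but a limit of this assay: it shows only that no inhibition strong enough to be measured was reached. The same is true of compound 2, whose figure is also a limit. Going by the values given here, both results therefore sit at the edge of what this assay can report, as the limit of > 10000 nM in this assay, at which 2 of the 2 values shown sit, sums up, so no ordering between the two compounds can be drawn, and no measured step between them exists.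

Compound 3 `COc1cc([C@H]2Oc3c(OC)cc(CCCO)cc3[C@@H]2CO[C@@H]2O[C@@H](C)[C@H](O)[C@@H](O)[C@H]2O)cc(OC)c1O` has not yet been measured. It differs from compound 1 only in how it is drawn in space: the two compounds have the same atoms and bonds and differ only in configuration as drawn: 2 of 7 stereo elements differ; a stereocentre at a saturated ring carbon is drawn R in compound 1 and S in compound 3; a stereocentre at a saturated ring carbon is drawn S in compound 1 and R in compound 3. The two compounds have the same atoms and bonds; 2 of 7 stereo elements differ, two stereocentres at saturated ring carbons being mirrored.

Since compound 1 only reaches a limit in this assay, nothing here points in a direction for the change from compound 1 to compound 3, and no step beyond the usual scatter is expected. Compound 3 is therefore expected to come out near the limit again, at about 20000 nM, within 8000 nM to 60000 nM, meaning an expected step that the limit leaves unreadable from compound 1 to compound 3.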

Compound 3, half-maximal inhibitory concentration: > 10000 nM
Compound 3: no number, only a limit (the forecaster's own chance of this, stated with the estimate: 80%); the middle value is on the limit's open side.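

In this assay compound 3 gives only a limit, > 10000 nM, and compound 1 gives a limit too, so no step can be read between compound 1 and compound 3. The compounds shown leave open whether mirroring the two stereocentres changes cytotoxicity at all, since none of them gives a measured number.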